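Triazole-linked hydroxamates: step to a trifluoromethylphenyl substituent

The source may hold more compounds than are shown below. What is called first, only, known or untested is meant among the compounds shown, and "the series" means these compounds.

Measured so far in an assay on Sf9 cells for inhibition of protein deacetylase HDAC6 (Homo sapiens), read by fluorescence, with a stated time of 40 min, tested at 100 nM; a lower number here means less inhibition, a higher number more inhibition at the concentration tested (going by the name of the read-out):
compound 1 `Cc1ccccc1-c1nc(CNc2ccc(C(=O)NO)cc2)n(-c2ccccc2)n1`, 53.2%
compound 2 `Cc1cccc(-n2nc(-c3ccccc3)nc2CNc2ccc(C(=O)NO)cc2)c1`, 66%
compound 3 `O=C(NO)c1ccc(NCc2nc(-c3ccccn3)nn2-c2ccccc2)cc1`, 58.6%

Compound 2 gives a number beyond the scatter above compound 1; against compound 3 the two values lie within the scatter of each other, so no order between compound 2 and compound 3 can be read from these numbers.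

Compound 4 `O=C(NO)c1ccc(NCc2nc(-c3ccccc3)nn2-c2ccc(C(F)(F)F)cc2)cc1` is not yet measured. It differs from compound 2 in one place: 4-(trifluoromethyl)phenyl in place of 3-methylphenyl on an aromatic nitrogen.

Among the measured compounds shown here, the single measured step, a number 5.4 percentage points higher from compound 1 to compound 3 (within the scatter), concerns the group on an aromatic carbon and lies within the scatter. For the measured compounds named here, no measured step touches the group on the aromatic nitrogen, so nothing speaks for or against a change from compound 2 to compound 4. The expected step in this assay is therefore a number 6 percentage points lower from compound 2 to compound 4 (within the scatter), not beyond the scatter, with a wide range. For compound 4 the estimate is 60%, between 40% and 78%.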

Compound 4, a percentage reported as inhibition, at one concentration (the size of the read-out at that concentration, not a potency): 38.9%
The estimate for compound 4 lay 21.1 percentage points above the measured number, and the stated range ends above it.
By their numbers in this assay, from the lowest: compound 4; then compounds 1, 3 and 2 (each within the scatter of the next, the first and the last beyond it).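

In this assay, among the compounds shown here, the change to 4-(trifluoromethyl)phenyl in place of 3-methylphenyl on the aromatic nitrogen gives a number 27.1 percentage points lower from compound 2 to compound 4 (beyond the scatter) and is the first measured step at this position. For the compounds shown here, the group on this nitrogen can therefore move the number beyond the scatter, whereas the only earlier step, a number 5.4 percentage points higher from compound 1 to compound 3 (within the scatter) and on an aromatic carbon, stayed within it. Nothing at hand gives a reason for the lower number at this position.

The change alters both the group on the phenyl ring and its place, so the compounds shown do not tell whether the trifluoromethyl group or its place goes with the lower number. From the compounds shown here alone, an aminophenyl or a chlorophenyl on the same nitrogen would extend the comparison, and whether the step holds with pyridin-2-yl or 2-methylphenyl on the aromatic carbon remains open.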